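This account rests on a few compounds, and the source may have more. Where it says the series, first, only, none or still open, it means among the compounds named here.

Measured so far in an assay on SK-BR-3 cells for inhibition of Aromatase (Homo sapiens); on this read-out higher numbers stand for weaker inhibition and lower numbers for stronger inhibition:
- compound 1 `CC(C)c1ccc(COc2cc([N+](=O)[O-])ccc2NS(C)(=O)=O)cc1`: 7450 nM
- compound 2 `CS(=O)(=O)Nc1ccc([N+](=O)[O-])cc1OCc1ccc(F)cc1`: 580 nM
- compound 3 `CS(=O)(=O)Nc1ccc([N+](=O)[O-])cc1OCc1ccc(-c2ccccc2)cc1`: 850 nM

Compound 2 gives the lowest number of the three in this assay, but its gap to compound 3 is within the scatter, a 1.5-fold higher number from compound 2 to compound 3 (0.17 log units; within the scatter), so the two cannot be ranked against each other. Only compound 1 stands apart, with higher numbers beyond the scatter: a 13-fold lower number from compound 1 to compound 2 (1.11 log units; beyond the scatter) and an 8.8-fold lower number from compound 1 to compound 3 (0.94 log units; beyond the scatter).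

Compound 4 `Cc1ccc(C)c(COc2cc([N+](=O)[O-])ccc2NS(C)(=O)=O)c1` is not yet measured. It differs from compound 2 in one place: 2,5-dimethylphenyl in place of 4-fluorophenyl on a saturated chain carbon bound to an oxygen on an aromatic ring.

Bearing on this change are the steps that alter the same ring. Replacing isopropyl with fluoro or phenyl lowered the number markedly from compound 1, while fluoro and phenyl are indistinguishable from each other within the scatter. The only variant carrying a carbon substituent of the alkyl type, compound 1, gave the highest number, and compound 4 carries two methyls on that ring. Compound 4 is therefore expected to give a higher number than compound 2 in this assay, estimated as a 2.6-fold higher number from compound 2 to compound 4 (0.41 log units; beyond the scatter), though a result within the scatter cannot be excluded given how little fluoro and phenyl differ.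

Estimate for compound 4 in this assay: 1500 nM, expected range 500 nM to 4500 nM.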

Compound 4, half-maximal inhibitory concentration: 370 nM
Compound 4: middle estimate off by 4.1-fold (0.61 log units), on the high side, outside the stated range (below it).
By their numbers in this assay, from the lowest: compounds 4, 2 and 3 (each within the scatter of the next, the first and the last beyond it); then compound 1.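

In this assay the change gives a 1.6-fold lower number from compound 2 to compound 4 (0.20 log units; within the scatter) and so leaves 2,5-dimethylphenyl and 4-fluorophenyl on a saturated chain carbon bound to an oxygen on an aromatic ring unranked against each other. Compound 4 is the first variant shown with alkyl groups on this ring that does not stand with compound 1, so carbon substituents of the alkyl type do not by themselves go with a high number: compound 1 gives 7450 nM and compound 4 gives 370 nM in this series. Nothing at hand accounts for the difference between these two aryl groups.

Compounds 1 and 4 differ in both the kind and the placing of their alkyl groups, so the set does not show which of the two matters; 4-isopropylphenyl stands alone, and a 4-methylphenyl or a 2-methylphenyl would help separate them. Also open is how this ring behaves with a methoxy group, an amine or a carboxylic acid, since every group shown here is either a halogen or made of carbon alone.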